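This account rests on a few compounds, and the source may have more. Where it says the series, first, only, none or still open, it means among the compounds named here.

Measured so far:
compound 1 `Cc1ccc(Nc2cc(C)nc(SCc3nc4ccccc4[nH]3)n2)cc1`: 56000 nM
compound 2 `Cc1cc(Nc2ccc(F)cc2)nc(SCc2nc3ccccc3[nH]2)n1`: 56200 nM
compound 3 `Cc1cc(NC(C)C)nc(SCc2nc3ccccc3[nH]2)n1`: > 100000 nM, a limit of the assay rather than a number

In a functional assay on PC-3 cells (Homo sapiens) for cytotoxicity, read by MTT assay, with a stated time of 72 h (a lower number here means a stronger inhibitor, a higher number a weaker inhibitor), compound 1 holds the lower of the two numbers, yet the step of a 1.0-fold higher number from compound 1 to compound 2 (0.00 log units; within the scatter) shows that exchanging one substituent on the aryl group for another leaves the read-out essentially unchanged. Compound 3 sits at the limit (the limit of > 100000 nM in this assay, at which 1 of the 3 values shown sits). The steps of an at least 1.7-fold higher number from compound 1 to compound 3 (0.25 log units; that floor lies within the scatter) and an at least 1.7-fold higher number from compound 2 to compound 3 (0.25 log units; that floor lies within the scatter) concern the isopropyl exchange, not the aryl substituent, so they bear less on what follows.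

Compound 4 `Cc1cc(Nc2ccc(Br)cc2)nc(SCc2nc3ccccc3[nH]2)n1` differs from compound 1 by bromo in place of methyl on an aromatic carbon. Among the measured compounds shown here, the only comparable precedent, the step of a 1.0-fold higher number from compound 1 to compound 2 (0.00 log units; within the scatter), lay within the scatter, so he expects the step of no change at the digits printed from compound 1 to compound 4 (within the scatter) to stay within the scatter as well. Compound 4 is therefore estimated at 56000 nM, between 25000 nM and 120000 nM.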

Compound 4, half-maximal inhibitory concentration: 37100 nM
Compound 4: middle estimate off by 1.5-fold (0.18 log units), on the high side; low and high end bracket the measured number.
By their numbers in this assay, from the lowest: compounds 4, 1 and 2 (each within the scatter of the next). At a limit, above all of these: compound 3.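

In this assay, bromo at this place on the aromatic ring stays within the scatter of both methyl and fluoro, with a 1.5-fold lower number from compound 1 to compound 4 (0.18 log units; within the scatter) and a 1.5-fold lower number from compound 2 to compound 4 (0.18 log units; within the scatter), so the three substituents are not told apart. The value of compound 3 is a limit and not a number: the limit of > 100000 nM in this assay, at which 1 of the 4 values shown sits. Even so, an at least 2.6-fold lower number from compound 3 to compound 4 (0.43 log units; beyond the scatter) is the first step among these compounds that lies beyond the scatter, and it concerns the group on the nitrogen rather than the substituent on the aryl group.

On these data alone, whether a methoxy group or a carboxylic acid at this place would move the number beyond the scatter stays open.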